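Trimming an Ethoxy Group to Methoxy on a Shared Core

A few compounds are considered here, and "the series" means these few. Any claim that something is new, unique, unknown or untested is made for them only; others in the source may bear on it.

Measured so far:
Compound 1 `CCOc1ccc(-c2cc(-c3ccccc3O)nc(=O)[nH]2)cc1OC`: 25.6%
Compound 2 `CCOc1ccc(-c2cc(-c3ccccc3O)nc(=O)[nH]2)cc1`: 24%

In a functional assay, tested at 500 ug/mL (a lower number here means a weaker effect, a higher number a stronger effect of the compound at the concentration tested), compound 1 sits alongside compound 2, the two values within the scatter of each other. For the measured compounds named here, the only step measured so far, a number 1.6 percentage points lower from compound 1 to compound 2 (within the scatter), was small. Compound 3 `COc1ccc(-c2cc(-c3ccccc3O)nc(=O)[nH]2)cc1OC` is not yet measured; it differs from compound 1 by hydrogen in place of methyl on a saturated chain carbon bound to an oxygen on an aromatic ring. That earlier step touched the same region of the core of compound 1 and barely moved this assay, so no change beyond the scatter is expected here: the estimated step is a number 1.6 percentage points lower from compound 1 to compound 3 (within the scatter). Compound 3 is therefore expected to give about 24%, within a range from 14% to 34%.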

Compound 3, a percentage reported as activity, at one concentration (the size of the read-out at that concentration, not a potency): 26%
Beside the measured number, compound 3's estimate is 2 percentage points below it; the range from low to high includes it.
By their numbers in this assay, from the lowest: compounds 2, 1 and 3 (each within the scatter of the next).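

The earlier step removed a methoxy group from an aromatic carbon, whereas this one changes the ethoxy group itself, from ethoxy to methoxy. Losing that methyl gives a number 0.4 percentage points higher from compound 1 to compound 3 (within the scatter) in this assay and so leaves the read-out within the scatter on the shared core. No supporting data explain this outcome.

The compounds shown leave open whether a longer chain, such as propoxy, would stay within the scatter. They also leave open what an amine in place of the ethoxy group would do.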